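The source may hold more compounds than are shown below. What is called first, only, known or untested is meant among the compounds shown, and "the series" means these compounds.

Working notes on the series in an ADME assay on cells (Peritoneal macrophage cell, Mus musculus, strain C57BL/6) for cytotoxicity, read by MTT assay, with a stated time of 48 h; on this read-out lower numbers stand for stronger inhibition and higher numbers for weaker inhibition. Compound 1 `C(=C1\CCCC\C1=N/Nc1nc(-c2ccccc2)cs1)\c1ccccc1` is the reference point. In this assay compound 1 reaches only the limit of the assay, > 100000 nM, and gives no number. Compound 2 `COc1ccc(-c2csc(N/N=C(\C)CCO)n2)cc1` behaves alike: in this assay compound 2 also stops at the assay limit, > 100000 nM. Compound 3 `C(=N/Nc1nc(-c2ccccc2)cs1)\C1CCCCC1` is the third measured member; in this assay compound 3 again sits at the limit, > 100000 nM. Among the measured compounds shown here, no pair of measured compounds differs in one place, so no step between measured values can be read. What the numbers show is the limit of > 100000 nM in this assay, at which 3 of the 3 values shown sit; compound 1 stands there together with compound 2 and compound 3, and none of the three can be ordered against the others.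

Compound 4 `COc1ccc(-c2csc(N/N=C3\CCCC\C3=C/c3ccccc3)n2)cc1` has not been measured in this assay. It differs from compound 1 by methoxy in place of hydrogen on an aromatic carbon, the phenyl becoming a 4-methoxyphenyl. For the measured compounds named here, no measured step covers this change. Going by the values given here, the expectation for the step from compound 1 to compound 4 is no movement beyond the scatter, a number no higher from compound 1 to compound 4 (the limit leaves the size open), since every value so far sits at the limit of > 100000 nM in this assay, at which 3 of the 3 values shown sit. Compound 4 is therefore expected to come out at 100000 nM, within 50000 nM to 200000 nM, and most likely to be reported once more as a limit rather than a number.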

Compound 4, half-maximal inhibitory concentration: > 100000 nM
Compound 4: no number, only a limit; the forecaster's own chance of this, stated with the estimate: 85%; the middle value lies on the limit itself.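

In this assay compound 4 gives > 100000 nM, a limit of the assay and not a number. Compound 1 also stands only at a limit, so no step between compound 1 and compound 4 can be read: the limit of > 100000 nM in this assay, at which 4 of the 4 values shown sit.

The compounds shown leave open whether methoxy in place of hydrogen on an aromatic carbon changes cytotoxicity in this assay at all.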